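The source may hold more compounds than are shown below. What is called first, only, known or untested is meant among the compounds shown, and "the series" means these compounds.

Measured compounds:
- compound 1, `COc1ccnc(Nc2ccc(Cl)c(OCC=C(C)C)c2)n1`, 9000 nM
- compound 2, `CC(C)=CCOc1cccc(Nc2nccs2)c1`, 23000 nM
- compound 3, `CC(C)=CCOc1cc(Nc2nccc(N)n2)ccc1Cl`, 500 nM

These three compounds were tested in a functional assay on MT2 cells (Homo sapiens) for cytotoxicity; a higher number here means that more compound is tolerated, a lower number that less compound is tolerated. Compound 2 gives the highest number of the three, so it is the best tolerated; compound 1 lies closest to it, and compound 3 lies furthest away. Among the measured compounds shown here, the only step between two compounds that differ in a single place is an 18-fold lower number from compound 1 to compound 3 (1.26 log units; beyond the scatter), a large drop in tolerated concentration.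

Compound 4, `COc1ccc(Nc2nccs2)cc1OCC=C(C)C`, has not yet been measured. It differs from compound 2 in one place: methoxy in place of hydrogen on an aromatic carbon. The methoxy group enters on the six-membered aromatic ring of carbon only, ortho to the (3-methylbut-2-en-1-yl)oxy group and para to the (1,3-thiazol-2-yl)amino group.

For the measured compounds named here, no measured step matches this change. The step from compound 1 to compound 3 concerns a different group on a different ring, so it gives no direct guide. Without a comparable precedent, no change beyond the scatter is expected in this assay. Compound 4 is therefore estimated at 17000 nM, within a range of 5000 nM to 50000 nM, which means an expected step of a 1.4-fold lower number from compound 2 to compound 4 (0.13 log units; within the scatter).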

Compound 4, half-maximal cytotoxic concentration: 42000 nM
For compound 4 the middle estimate is 2.5-fold (0.39 log units) below the measured one; the measured number falls inside the stated range.
By their numbers in this assay, from the lowest: compound 3; then compound 1; then compounds 2 and 4 (each within the scatter of the next).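

In this assay, placing a methoxy group on the six-membered aromatic ring of carbon only, ortho to the (3-methylbut-2-en-1-yl)oxy group and para to the (1,3-thiazol-2-yl)amino group, gives a 1.8-fold higher number from compound 2 to compound 4 (0.26 log units; within the scatter). Among the compounds shown here, this position therefore takes a methoxy group in place of hydrogen with no readable change in the tolerated concentration, something the earlier compounds could not show, as their only single-place step involved a different group on a different ring. No available information bears on this result.

From the compounds shown here alone, whether an amine, a carboxylic acid or a longer chain such as butoxy at this position would shift the number beyond the scatter remains open. A single step also cannot show whether methoxy would be tolerated equally on a different core.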